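The compounds below may be only part of what the source reports. "The series", "measured", "known", "first", "only" and "open" are said of these compounds alone.

The study starts from compound 1, `CCC[C@@H](OC(C)=O)C1=C(Br)[C@@](C)(OC)OC1=O`, a brominated butenolide carrying an acetoxy group on its side chain. Among the measured compounds shown here, in a functional assay on KB cells (Homo sapiens) for cytotoxicity (on this read-out lower numbers stand for an effect already at smaller amounts and higher numbers for an effect only at larger amounts of compound), compound 1 gives 10.7 ug/mL, the only numerical value that has been obtained. Compound 2, `CCCCC1=C(Br)C(=C(Br)Br)OC1=O`, reaches only a limit of the assay, > 20 ug/mL, so it offers no number to compare. For the measured compounds named here, the evidence on hand is therefore just (the limit of > 20 ug/mL in this assay, at which 1 of the 2 values shown sits), and no step between two measured compounds can be drawn.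

Compound 3, `CCC[C@@H](OC(C)=O)C1=C(Br)[C@](OC)(C(Br)Br)OC1=O`, is the next compound to be tested. Compared with compound 1 it carries dibromomethyl in place of methyl on a saturated ring carbon. Going by the values given here, with no measured step to rely on, the expectation for this change in this assay rests on compound 1 alone. The estimated step of a 1.2-fold higher number from compound 1 to compound 3 (0.08 log units; within the scatter) is expected to be small, pointing at most toward a weaker effect and not clearly beyond the scatter of repeated measurements. Compound 3 is therefore estimated at 13 ug/mL, with a plausible range from 5 ug/mL to 30 ug/mL.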

Compound 3, concentration for half-maximal effect: 5.3 ug/mL
Compound 3: middle estimate off by 2.5-fold (0.39 log units), on the high side; measured number inside the range.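

Among the compounds shown here, with dibromomethyl in place of methyl on the saturated ring carbon next to the ring oxygen, this assay records a 2.0-fold lower number from compound 1 to compound 3 (0.31 log units; beyond the scatter), the first step that can be read at all. This shows that the position accepts the larger group, with its two bromine atoms, without any loss of effect; the number in fact moves modestly toward an effect at smaller amounts of compound. Nothing measured on these compounds accounts for this step, so it stands as an observation on one pair of compounds.

On these data alone, it remains open whether the bromine atoms themselves matter here, which a bromomethyl or a tribromomethyl group at this carbon could test, and whether a group without halogen, such as a longer chain, would move the number in the same way. Also open, as far as these compounds go, is whether the same change would give a similar step if the acetoxy group on the side chain gave way to a hydroxyl group or an amine; this single pair is all that speaks to the change so far.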